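The source may report more compounds than this note shows. Statements on the series, on what has been measured and on what is new or still open speak of the compounds shown alone.

Three compounds have been measured in a functional assay on SK-N-SH cells (Homo sapiens) for cytotoxicity, read by MTT assay, with a stated time of 48 h; on this read-out higher numbers stand for weaker inhibition and lower numbers for stronger inhibition:

compound 1 `COc1cccc2[nH]cc(C3(c4c[nH]c5cccc(OC)c45)C(=O)Nc4ccccc43)c12` gives 4700 nM;
compound 2 `COc1ccc2c(C3(c4c[nH]c5cc(OC)ccc45)C(=O)Nc4ccccc43)c[nH]c2c1` gives 13600 nM;
compound 3 `O=C1Nc2ccccc2C1(c1c[nH]c2ccc(Cl)cc12)c1c[nH]c2ccc(Cl)cc12` gives 9400 nM.

On these numbers compound 1 holds the lowest value of the three. Compound 3 sits within the usual scatter of compound 1, so the two cannot be told apart on this read-out, whereas compound 2 stands beyond the scatter and thus at a clearly higher number. Among the compounds with values here, compounds 1 and 2 each carry two methoxy groups, compound 3 two chlorines, but no pair among them differs in only one place, so the measured set gives no single-point step against which a small change on the shared core could be gauged.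

Compound 4 `COc1cccc2[nH]cc(C3(c4c[nH]c5cccc(OC)c45)C(=O)Nc4ccc(F)cc43)c12` differs from compound 1 in one place: fluoro in place of hydrogen on an aromatic carbon. The entering group is a single heavy atom, and the rest of the molecule is unchanged. Within the data shown here, with no comparable step among the measured compounds, the step from compound 1 to compound 4 in this assay is expected to be a 1.1-fold lower number from compound 1 to compound 4 (0.05 log units; within the scatter), which amounts to none beyond the scatter, and no direction can be read from the data. Compound 4 is therefore estimated in this assay at 4200 nM, with a range from 1500 nM to 12000 nM.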

Compound 4, half-maximal inhibitory concentration: 12100 nM
Compound 4: middle estimate off by 2.9-fold (0.46 log units), on the low side; the measured number lies above the stated range.
By their numbers in this assay, from the lowest: compounds 1, 3, 4 and 2 (each within the scatter of the next, the first and the last beyond it).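

In this assay, within the data shown here, this is the first step in the set that changes a single place, and it shows that this aromatic carbon of the shared core does not tolerate every change without effect. Fluoro in place of hydrogen gives a 2.6-fold higher number from compound 1 to compound 4 (0.41 log units; beyond the scatter), a modest shift towards weaker inhibition that lies beyond the usual scatter, although the entering group is a single heavy atom and the rest of the molecule is unchanged. There is no evidence here to account for this shift.

The compounds shown leave open whether the shift belongs to fluoro itself or would appear with any group on this carbon, such as a nitrile, an amine or a carboxylic acid, each of which would show whether the number keeps rising with a different group or moves the other way. They also leave open whether fluoro on the other aromatic carbons of this ring, or on this same carbon with the chlorines of compound 3 in place of the methoxy groups, would give a step of similar size and direction.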